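From a Trifluorobutyl Chain to a Cyclohexyl Ring

The compounds below may be only part of what the source reports. "The series", "measured", "known", "first", "only" and "open" are said of these compounds alone.

In a functional assay on HT-29 cells (Homo sapiens) for inhibition, read by luminescence and CellTiter-Glo, with a stated time of 24 h (on this read-out lower numbers stand for an effect already at smaller amounts and higher numbers for an effect only at larger amounts of compound), compound 1 (`CC(C)CCn1nc(C(=O)N[C@H]2COc3ccccc3N(C)C2=S)nc1Cc1ccccc1`) gives 3640 nM as its result, and compound 2 (`CN1C(=S)[C@@H](NC(=O)c2nc(Cc3ccccc3)n(CCCO)n2)COc2ccccc21`) gives 209 nM as its result. Compound 3 (`CN1C(=S)[C@@H](NC(=O)c2nc(Cc3ccccc3)n(CCCC(F)(F)F)n2)COc2ccccc21`) gives 2380 nM and therefore stands with compound 1, well apart from compound 2. The step of a 1.5-fold lower number from compound 1 to compound 3 (0.18 log units; within the scatter) is no real separation, whereas the step of an 11-fold higher number from compound 2 to compound 3 (1.06 log units; beyond the scatter) is large.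

Compound 4 (`CN1C(=S)[C@@H](NC(=O)c2nc(Cc3ccccc3)n(C3CCCCC3)n2)COc2ccccc21`) keeps the shared core and differs in one group. The difference is cyclohexyl in place of 4,4,4-trifluorobutyl on an aromatic nitrogen and places cyclohexyl where 4,4,4-trifluorobutyl stood on an aromatic nitrogen.

Within the data shown here, no measured compound carries a ring at this place, so the three steps offer only indirect guidance. Exchanging one chain without a hydroxy group for another gave the small step of a 1.5-fold lower number from compound 1 to compound 3 (0.18 log units; within the scatter) in this small set. Only the hydroxy-ended chain of compound 2 stands apart, with the large step of a 17-fold lower number from compound 1 to compound 2 (1.24 log units; beyond the scatter) leading to it. Cyclohexyl also has no hydroxy group, so the expected change is a 1.2-fold lower number from compound 3 to compound 4 (0.08 log units; within the scatter) and no shift beyond the usual scatter is anticipated. The untested ring justifies a wide range. For compound 4 the estimated value is 2000 nM within an expected range of 500 nM to 8000 nM in this measurement.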

Compound 4, half-maximal effective concentration: 4000 nM
Compound 4: the middle estimate sits 2.0-fold (0.30 log units) below what was measured, within the range that was stated.
By their numbers in this assay, from the lowest: compound 2; then compounds 3, 1 and 4 (each within the scatter of the next).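

In this assay, a ring on this aromatic nitrogen does not separate compound 4 from the two compounds that carry open chains without a hydroxy group: the steps of a 1.7-fold higher number from compound 3 to compound 4 (0.23 log units; within the scatter) and a 1.1-fold higher number from compound 1 to compound 4 (0.04 log units; within the scatter) are no real change. Cyclohexyl, 4,4,4-trifluorobutyl and isopentyl therefore form one group in these results, so among these compounds neither a ring of carbon only nor a fluorinated end on the chain moves the number away from that of the branched chain. Against this group, compound 2 stands alone, as the large step of a 19-fold higher number from compound 2 to compound 4 (1.28 log units; beyond the scatter) shows, and among the four compounds only its 3-hydroxypropyl chain ends in a hydroxy group, although nothing available here explains the link between that group and the lower number.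

On these data alone, it remains open whether another group at the end of the chain, such as an amine or a carboxylic acid, would give a number close to that of compound 2. As far as these compounds go, it is also open whether a hydroxy group on a cyclohexyl ring, or on a longer chain, would keep the large step seen with the 3-hydroxypropyl chain.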